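From 3-bromobenzyl to 4-(trifluoromethyl)benzyl

A few compounds are considered here, and "the series" means these few. Any claim that something is new, unique, unknown or untested is made for them only; others in the source may bear on it.

For the measured compounds named here, in an ADME assay on GES1 cells (Homo sapiens) for inhibition, read by MTT assay, with a stated time of 72 h (on this read-out higher numbers stand for weaker inhibition and lower numbers for stronger inhibition), compound 1 `Cc1cc(Nc2cc(-c3ccccc3)[nH]n2)n2nc(SCc3c(Cl)cccc3Cl)nc2n1` gives 39600 nM, the only true number so far. Compound 2 `Cc1cc(Nc2cc(-c3ccccc3)[nH]n2)n2nc(SCc3cccc(Br)c3)nc2n1` stands at > 50000 nM, which is a limit of the assay and not a number. Compound 3 `Cc1cc(Nc2cc(C(C)(C)C)[nH]n2)n2nc(SCc3ccc(Br)cc3)nc2n1` reads > 50000 nM, likewise a limit. The small set therefore shows (the limit of > 50000 nM in this assay, at which 2 of the 3 values shown sit).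

Compound 4 `Cc1cc(Nc2cc(-c3ccccc3)[nH]n2)n2nc(SCc3ccc(C(F)(F)F)cc3)nc2n1` comes from compound 2 through one change on a saturated chain carbon bound to a sulfur: 4-(trifluoromethyl)phenyl in place of 3-bromophenyl on a saturated chain carbon bound to a sulfur. Going by the values given here, the one measured step at that place, an at least 1.2-fold higher number from compound 1 to compound 2 (0.10 log units; that floor lies within the scatter), has a floor that stays within the scatter, so no step beyond the scatter is expected in this assay. With the starting point only a limit, the size of this step remains loosely defined, and a further limit is a likely result. The expected step is a number no higher from compound 2 to compound 4 (the limit leaves the size open). For compound 4 the estimated value is 50000 nM, with an expected range from 25000 nM to 100000 nM.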

Compound 4, half-maximal inhibitory concentration: 42700 nM
Beside the measured number, compound 4's estimate is 1.2-fold (0.07 log units) above it; measured number inside the range.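

In this assay, two true numbers now stand on a saturated chain carbon bound to a sulfur, and the step between them can be read: a 1.1-fold higher number from compound 1 to compound 4 (0.03 log units; within the scatter). As far as these compounds go, the step from the 3-bromophenyl compound reads an at least 1.1-fold lower number from compound 2 to compound 4 (0.06 log units; that floor lies within the scatter), and its size stays open because one of its ends is a limit: the limit of > 50000 nM in this assay, at which 2 of the 4 values shown sit. Among compound 1, compound 2 and compound 4, no change at this place has yet given a step beyond the scatter.

From the compounds shown here alone, whether an amine, a carboxylic acid or a longer chain in place of the substituted phenyl would move the number beyond the scatter remains open. Compound 3 differs from compound 4 in more than one place, so it says nothing about this change.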